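Piperidinylpiperidine Sulfonamides: Cytotoxicity Stays Beyond the Limits

The source may hold more compounds than are shown below. What is called first, only, known or untested is meant among the compounds shown, and "the series" means these compounds.

Compound 1, `Cc1cccc(S(=O)(=O)N2CCC(N3CCC(C)CC3)CC2)c1`, gives > 5000 nM in an ADME assay on HCT-116 cells (Homo sapiens) for cytotoxicity, read by CellTiter-Glo, with a stated time of 72 h (on this read-out higher numbers stand for weaker inhibition and lower numbers for stronger inhibition), a limit of the assay rather than a number.
Compound 2, `CC1CCN(C2CCN(S(=O)(=O)c3cccnc3F)CC2)CC1`, gives > 10000 nM in this assay, again only a limit.
Compound 3, `CC1CCN(C2CCN(S(=O)(=O)c3ccc(Cl)nc3)CC2)CC1`, gives > 10000 nM in this assay, once more a limit.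

Compound 3 therefore stands nowhere that can be ranked: its result is a limit, and the two other values shown are limits as well, so none of the three can be set above or below another. The steps that lead to compound 3 are a step that the two limits leave unreadable from compound 1 to compound 3 and a step that the two limits leave unreadable from compound 2 to compound 3, and the remaining pair shows a step that the two limits leave unreadable from compound 1 to compound 2. Two of the three values sit at the limit of > 10000 nM in this assay, at which 2 of the 3 values shown sit, and one at the limit of > 5000 nM in this assay, at which 1 of the 3 values shown sits.

Compound 4, `CCc1ccc(S(=O)(=O)N2CCC(N3CCC(C)CC3)CC2)cc1`, has not yet been measured in this assay. It differs from compound 3 by 4-ethylphenyl in place of 6-chloropyridin-3-yl on a sulfonyl sulfur. Among the measured compounds shown here, no measured step around this position can be read, so no step of any size or direction beyond the scatter is expected from compound 3 to compound 4, and the expected step that the limit leaves unreadable from compound 3 to compound 4 is written only as a formality. Since compound 1, which carries a 3-methylphenyl on the same sulfonyl sulfur, also sits at a limit, compound 4 is expected to give about 15000 nM, with a range from 4000 nM to 60000 nM, most likely reported as a limit.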

Compound 4, half-maximal inhibitory concentration: > 5000 nM
Compound 4 was reported as a limit (the forecaster's own chance of this, stated with the estimate: 85%); the middle value is on the limit's open side.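

Compound 4, like compound 1, compound 2 and compound 3, is reported only as a limit, so none of the steps from those three compounds to compound 4 can be read in this assay: the limit of > 5000 nM in this assay, at which 2 of the 4 values shown sit.

The compounds shown leave open whether the groups on the sulfonyl sulfur differ at all in this assay.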